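Lengthening the imidazole alkyl chain: methyl to butyl

The source may report more compounds than this note shows. Statements on the series, on what has been measured and on what is new or still open speak of the compounds shown alone.

Compound 1: `Cc1nc(C)c(CN2CCN(c3cccc4[nH]c(-c5ccc(C(C)(C)C)cc5)nc34)CC2)o1`, 31 nM
Compound 2: `CCc1nc(C)c(CN2CCN(c3cccc4[nH]c(-c5ccc(C(C)(C)C)cc5)nc34)CC2)s1`, 20 nM
Compound 3: `Cc1nc(CN2CCN(c3cccc4[nH]c(-c5ccc(C(C)(C)C)cc5)nc34)CC2)cn1C`, 10 nM

In an assay on isolated protein for displacement of a labelled ligand from Gonadotropin-releasing hormone receptor (Homo sapiens) (a lower number here means a stronger inhibitor, a higher number a weaker inhibitor), compound 3 gives the lowest number of the three. Its nearest neighbour is compound 2, with a 2.0-fold lower number from compound 2 to compound 3 (0.30 log units; within the scatter), and its furthest is compound 1, with a 3.1-fold lower number from compound 1 to compound 3 (0.49 log units; beyond the scatter); only the latter gap is beyond the scatter, so compound 3 cannot be called the strongest outright.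

Compound 4, `CCCCc1nc(CN2CCN(c3cccc4[nH]c(-c5ccc(C(C)(C)C)cc5)nc34)CC2)cn1C`, differs from compound 3 by propyl in place of hydrogen on a saturated chain carbon bound to an aromatic carbon. Among the compounds with values here, no measured step in this set changes an alkyl chain on the imidazole; the one alkyl lengthening on record, a 1.6-fold lower number from compound 1 to compound 2 (0.19 log units; within the scatter), also swaps the ring itself and sits within the scatter. The measured steps therefore bear on this change only loosely, and they suggest that the heteroaryl group on this chain carbon tolerates modest variation without large shifts in this assay.

Compound 4 is thus expected to stay close to compound 3, with a 1.3-fold lower number from compound 3 to compound 4 (0.10 log units; within the scatter), a step not beyond the scatter in either direction. Compound 4 is estimated at 8 nM in this assay, within a range of 3 nM to 25 nM.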

Compound 4, half-maximal inhibitory concentration: 26 nM
The estimate for compound 4 lay 3.3-fold (0.51 log units) below the measured number, outside the stated range (above it).
By their numbers in this assay, from the lowest: compounds 3, 2, 4 and 1 (each within the scatter of the next, the first and the last beyond it).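

In this assay, within the data shown here, the change from 1,2-dimethyl-1H-imidazol-4-yl to 2-butyl-1-methyl-1H-imidazol-4-yl gives (a 2.6-fold higher number from compound 3 to compound 4 (0.41 log units; beyond the scatter)), so this is the first alkyl change confined to the imidazole, and it shows that methyl to butyl on this group carries a modest cost rather than being tolerated without effect. The butyl compound also no longer stands apart from the other heteroaryl groups: compound 3 had a modest edge (a 3.1-fold lower number from compound 1 to compound 3 (0.49 log units; beyond the scatter)), but the steps (a 1.2-fold lower number from compound 1 to compound 4 (0.08 log units; within the scatter)) and (a 1.3-fold higher number from compound 2 to compound 4 (0.11 log units; within the scatter)) both lie within the scatter, so compound 4 cannot be ordered against compound 1 or compound 2. Nothing available here explains why the longer chain raises the number.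

The compounds shown leave open whether the number climbs steadily with chain length or changes only past a certain length, which an ethyl or propyl chain on this imidazole would settle. They also leave open whether a branched isopropyl group, a cyclopropyl ring or a chain ending in a hydroxyl or an amine would recover the value of compound 3 (10 nM) at this position.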